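The compounds below may be only part of what the source reports. "The series", "measured", "known", "first", "only" and "open" are said of these compounds alone.

Of the compounds shown here, three sharing one core have been tested in an ADME assay on HEL cells (Homo sapiens) for cytotoxicity, with a stated time of 3 days; a lower number here means that less compound is tolerated, a higher number that more compound is tolerated. Compound 1 `CCC1(Cc2ccccc2)OS(=O)(=O)C=C1OCCCCc1ccccc1` reaches only a limit of the assay, >= 20000 nM. Compound 2 `CCC1(Cc2ccccc2)OS(=O)(=O)C=C1OC` likewise stops at a limit, > 400000 nM. Compound 3 `CCC1(Cc2ccccc2)OS(=O)(=O)C=C1OCc1ccc(OC)cc1` also gives only a limit, >= 200000 nM. With every reading a limit, the steps a step that the two limits leave unreadable from compound 1 to compound 3 and a step that the two limits leave unreadable from compound 2 to compound 3 have no readable size, and compound 3 cannot be placed above or below the others. Compound 4 `CCC1(Cc2ccccc2)OS(=O)(=O)C=C1OCc1ccccc1Cl` differs from compound 3 in one place: 2-chlorophenyl in place of 4-methoxyphenyl on a saturated chain carbon bound to an oxygen on an unsaturated carbon. The measured steps at this same place give no readable size, so no step beyond the scatter is expected in this assay. Compound 4 is therefore estimated at 200000 nM, within 20000 nM to 400000 nM, which means an expected step of a number no higher from compound 3 to compound 4 (the limit leaves the size open).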

Compound 4, minimum cytotoxic concentration: >= 20000 nM
Compound 4: a limit, no number; the forecaster's own chance of this, stated with the estimate: 80%; the middle value is on the limit's open side.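

Among these compounds, compound 4 gives only a limit, so no step from compound 1, compound 2 or compound 3 to compound 4 can be read: the limit of >= 20000 nM in this assay, at which 2 of the 4 values shown sit. The compounds shown leave open whether the groups at this place change the minimum cytotoxic concentration in this assay at all.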